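Bromo Replaces Methyl on a Weakly Inhibiting Scaffold

This account rests on a few compounds, and the source may have more. Where it says the series, first, only, none or still open, it means among the compounds named here.

Compound 1 `Cc1ccc2occ([C@@H]3C[C@H](c4ccccc4)ON3c3ccccc3)c(=O)c2c1` is the reference point: in a functional assay on A549 cells (Homo sapiens) for inhibition, read by sulforhodamine B assay, with a stated time of 48 h (on this read-out higher numbers stand for weaker inhibition and lower numbers for stronger inhibition), compound 1 gives 49000 nM. Compound 3 `O=c1c([C@@H]2C[C@H](c3ccccc3)ON2c2ccccc2)coc2ccccc12` lacks the methyl, and in this assay compound 3 reaches only the assay limit of > 60000 nM. Compound 2 `Cc1ccc2occ([C@@H]3[C@H]4C(=O)N(c5ccccc5)C(=O)[C@H]4ON3c3ccccc3)c(=O)c2c1` likewise reports only a limit, > 60000 nM in this assay. It sits at the limit of > 60000 nM in this assay, at which 2 of the 3 values shown sit, so its true number is not known. Compound 4 `O=C1[C@H]2[C@H](ON(c3ccccc3)[C@@H]2c2coc3ccc(Br)cc3c2=O)C(=O)N1c1ccccc1` differs from compound 2 by bromo in place of methyl on an aromatic carbon. Within the data shown here, no measured step exchanges methyl for bromo; the only step touching the methyl, an at least 1.2-fold higher number from compound 1 to compound 3 (0.08 log units; that floor lies within the scatter), stays within the scatter. Compound 4 is therefore expected to remain near the limit, with an estimated step that the limit leaves unreadable from compound 2 to compound 4 and an expected value of 80000 nM, between 30000 nM and 200000 nM.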

Compound 4, half-maximal inhibitory concentration: 17000 nM
Compound 4: middle estimate off by 4.7-fold (0.67 log units), on the high side, outside the stated range (below it).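

In this assay this position on the six-membered aromatic ring of carbon only does respond: bromo in place of methyl gives an at least 3.5-fold lower number from compound 2 to compound 4 (0.54 log units; beyond the scatter) with the rest of the molecule unchanged. Among these compounds, the floor of the earlier step at this position, which removes the methyl, stayed within the scatter, so this is the first change here that reads clearly. Its full size remains unknown, because compound 2 stands at a limit: the limit of > 60000 nM in this assay, at which 2 of the 4 values shown sit.

As far as these compounds go, whether chloro or methoxy at this position would act like bromo remains open. So does whether bromo would lower the number on the core of compound 1.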